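The source may report more compounds than this note shows. Statements on the series, on what has been measured and on what is new or still open speak of the compounds shown alone.

Compound 2 `CN(C)C/C=C/C(=O)Nc1cccc(S(=O)(=O)N2CCC(NC(=O)c3n[nH]cc3NC(=O)c3c(Cl)cc(Cl)cc3Cl)CC2)c1` is the starting point. In an assay on HEK293 cells for inhibition of cyclin-dependent kinase 14 (Homo sapiens), with a stated time of 4 h (a higher number here means a weaker inhibitor, a lower number a stronger inhibitor), compound 2 gives >= 500 nM, which is a limit of the assay and not a number. Compound 1 `CCC(=O)Nc1cccc(CN2CCC(NC(=O)c3n[nH]cc3NC(=O)c3c(Cl)cccc3Cl)CC2)c1` gives in this assay > 1000 nM, also a limit. Compound 3 `CN(C)CC/C=C/C(=O)Nc1ccc(S(=O)(=O)N2CC[C@@H](NC(=O)c3n[nH]cc3NC(=O)c3c(Cl)cccc3Cl)C2)cc1` gives in this assay > 1000 nM, again a limit. Among the compounds with values here, compound 2 thus stands alone at the limit of >= 500 nM in this assay, at which 1 of the 3 values shown sits, while the other two sit at the limit of > 1000 nM in this assay, at which 2 of the 3 values shown sit; no numbered value exists among the three, and no single-change step has been measured. Compound 4 `COc1cccc(Cl)c1C(=O)Nc1c[nH]nc1C(=O)NC1CCN(S(=O)(=O)c2cccc(NC(=O)/C=C/CN(C)C)c2)CC1` differs from compound 2 by 2-chloro-6-methoxyphenyl in place of 2,4,6-trichlorophenyl on a carbonyl carbon. With nothing measured to steer the direction, compound 4 is expected to stay at a similar level, an estimate of 1500 nM with a range from 400 nM to 6000 nM. The step that the limit leaves unreadable from compound 2 to compound 4 is expected to be none beyond the scatter.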

Compound 4, half-maximal inhibitory concentration: 50 nM
Compound 4: middle estimate off by 30-fold (1.48 log units), on the high side; measured number below the stated range.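

In this assay, 2-chloro-6-methoxyphenyl in place of 2,4,6-trichlorophenyl on a carbonyl carbon gives an at least 10-fold lower number from compound 2 to compound 4 (1.00 log units; beyond the scatter). This shows that the group on this carbonyl can move the read-out beyond the scatter, and compound 4, at 50 nM, holds the only numbered value among the compounds shown. The full size of the step stays unknown, since compound 2 gives only a limit: the limit of >= 500 nM in this assay, at which 1 of the 4 values shown sits.

The compounds shown do not separate the gain of the methoxy group from the loss of chlorine. As far as these compounds go, whether an ethoxy or a hydroxyl group in place of the methoxy group would keep the level of compound 4 also stays open.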